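Acetyl in Place of Methoxy on the Phenyl Ring

A few compounds are considered here, and "the series" means these few. Any claim that something is new, unique, unknown or untested is made for them only; others in the source may bear on it.

Compound 1 `c1ccc(-c2cn3ccnc3c(-c3ccc4ncn(C5CCCCC5)c4c3)n2)cc1` gives 57.1% in a functional assay on BT-549 cells (Homo sapiens) for inhibition, read by sulforhodamine B assay, with a stated time of 48 h, tested at 10 uM; a higher number here means more inhibition at the concentration tested (going by the name of the read-out), a lower number less inhibition.
Compound 2 `COc1ccc(-c2cn3ccnc3c(-c3ccc4ncn(C5CCCCC5)c4c3)n2)cc1` gives 68.9% in this assay.

Among the two measured compounds, compound 2 stands highest; its only neighbour is compound 1, and the rise a number 11.8 percentage points higher from compound 1 to compound 2 (beyond the scatter) lies beyond the scatter. The next compound, compound 3 `CC(=O)c1ccc(-c2cn3ccnc3c(-c3ccc4ncn(C5CCCCC5)c4c3)n2)cc1`, differs from compound 2 by acetyl in place of methoxy on an aromatic carbon. For the measured compounds named here, the one measured step bears on this change only loosely: it shows that putting a methoxy at this place, where compound 1 carries hydrogen, gave a modest gain of a number 11.8 percentage points higher from compound 1 to compound 2 (beyond the scatter), but nothing measured tells how an acetyl at the same place compares with a methoxy. With no direct guide, the expected step of a number 4.9 percentage points lower from compound 2 to compound 3 (within the scatter) in this assay is small, within the scatter, and leaning slightly downward. Compound 3 is therefore estimated at 64%, within a range from 45% to 80%.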

Compound 3, a percentage reported as inhibition, at one concentration (the size of the read-out at that concentration, not a potency): 4.68%
Beside the measured number, compound 3's estimate is 59.3 percentage points above it; measured number outside the range, below it.
By their numbers in this assay, from the lowest: compound 3; then compound 1; then compound 2.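

The methoxy step alone suggested only a modest response at this aromatic carbon, para to a large group, but the acetyl shows that the position is far from indifferent to what it carries. In this assay the change from methoxy to acetyl gives a number 64.2 percentage points lower from compound 2 to compound 3 (beyond the scatter) and the change from hydrogen to acetyl gives a number 52.4 percentage points lower from compound 1 to compound 3 (beyond the scatter) so the acetyl compares poorly not only with methoxy but also with plain hydrogen. No measurement at hand explains this drop.

The compounds shown leave open how an amine, a carboxylic acid or a chlorine atom at this carbon would compare with methoxy and acetyl, and so whether acetyl is a lone exception or part of a wider trend. They also leave open whether the drop would hold at other concentrations or in other cell lines.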